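A few compounds are considered here, and "the series" means these few. Any claim that something is new, unique, unknown or untested is made for them only; others in the source may bear on it.

Compound 1 `CCOC(=O)C1=C(C)N/C(=C/c2cc(C)n(-c3ccc(F)cc3F)c2C)C1=O` has been measured in a physicochemical assay for lipophilicity, read by HPLC, at pH 7.4 (on this read-out lower numbers stand for lower lipophilicity and higher numbers for higher lipophilicity), and gives 3. Compound 2 `CCOC(=O)C1=C(C)N/C(=C/c2cc(C)n(-c3ccc(SC)cc3)c2C)C1=O` stands without a number in this assay, where it gives "not determined" (no result reported), so no measured value anchors it. Compound 3 `CCOC(=O)C1=C(C)N/C(=C/c2cc(C)n(-c3ccncc3)c2C)C1=O` differs from compound 2 by a single exchange: pyridin-4-yl in place of 4-(methylsulfanyl)phenyl on an aromatic nitrogen. Within the data shown here, no measured pair shares this exchange, so the expected step rests on the structures alone, and a sizable shift downward in this assay, well beyond the usual scatter, is expected. Compound 3 is therefore expected to give about 1.5 in this assay, within a range from 0.8 to 2.3.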

Compound 3, distribution coefficient: 3.2
Estimate against measurement, compound 3: 1.70 log units below, and the stated range ends below it.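

In this assay, pyridin-4-yl in place of 2,4-difluorophenyl on the aromatic nitrogen gives a number 0.20 log units higher from compound 1 to compound 3 (within the scatter), so these two rings read alike at this position. Compound 2 has no number, so the exchange from it to compound 3 cannot be read. Nothing available explains this result. From the compounds shown here alone, it remains open whether 4-(methylsulfanyl)phenyl reads like these two rings. Also open, going by these compounds, is whether a different kind of group on this nitrogen, such as a simple amine chain or a phenyl ring bearing a carboxylic acid, would shift the number.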